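A few compounds are considered here, and "the series" means these few. Any claim that something is new, unique, unknown or untested is made for them only; others in the source may bear on it.

Measured in a functional assay on Jurkat cells (Homo sapiens); on this read-out higher numbers stand for weaker inhibition and lower numbers for stronger inhibition:

- compound 1 `CC(C)[C@H](NC(=O)COc1cccc2ccccc12)C(=O)N[C@@H](CC(=O)O)C(=O)COc1ccc(OC(F)(F)F)cc1` gives 29100 nM
- compound 2 `CC(C)[C@H](NC(=O)COc1cccc2ccccc12)C(=O)N[C@@H](CC(=O)O)C(=O)COc1c(F)cccc1F` gives 2040 nM
- compound 3 `CC(C)[C@H](NC(=O)COc1cccc2ccccc12)C(=O)N[C@@H](CC(=O)O)C(=O)COc1ccc(F)c(F)c1F` gives 35800 nM

Compound 3 sits at the high end of these numbers, which means weak inhibition. There is a 1.2-fold higher number from compound 1 to compound 3 (0.09 log units; within the scatter), so those two form one group. For the measured compounds named here, only one measured compound lies clearly lower, with an 18-fold higher number from compound 2 to compound 3 (1.24 log units; beyond the scatter), a large step.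

The next compound is compound 4 `CC(C)[C@H](NC(=O)COc1cccc2ccccc12)C(=O)N[C@@H](CC(=O)O)C(=O)COc1c(F)c(F)cc(F)c1F`, which carries 2,3,5,6-tetrafluorophenyl in place of 2,3,4-trifluorophenyl on an oxygen on a saturated carbon. The counted change is 2,3,5,6-tetrafluorophenyl in place of 2,3,4-trifluorophenyl on an oxygen on a saturated carbon, and the rest of the molecule stays the same.

Going by the values given here, only this group varies across the set, so the measured steps are the only guide. They show that it can move the number a long way, with a 14-fold lower number from compound 1 to compound 2 (1.15 log units; beyond the scatter), also a large step. Among the compounds with values here, no measured compound carries the entering group. Its name contains every position named in 2,6-difluorophenyl, so compound 2 at 2040 nM is taken as the closest reference, though this is a weak basis for a prediction.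

A large drop is therefore expected, and the estimate means an 18-fold lower number from compound 3 to compound 4 (1.25 log units; beyond the scatter) in this assay. For compound 4 the estimated value is 2000 nM, with an expected range from 300 nM to 15000 nM as its limits.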

Compound 4, half-maximal inhibitory concentration: 4500 nM
For compound 4 the middle estimate is 2.3-fold (0.35 log units) below the measured one; the measured number falls inside the stated range.
By their numbers in this assay, from the lowest: compound 2; then compound 4; then compounds 1 and 3 (each within the scatter of the next).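

In this assay, moving to the 2,3,5,6-tetrafluorophenyl group gives an 8.0-fold lower number from compound 3 to compound 4 (0.90 log units; beyond the scatter), so the exact arrangement of fluorines on this ring matters, and the name with the most fluorines does not give the highest number. The new group sits between the earlier ones, with a 2.2-fold higher number from compound 2 to compound 4 (0.34 log units; beyond the scatter) and a 6.5-fold lower number from compound 1 to compound 4 (0.81 log units; beyond the scatter), so among these four compounds the two groups whose names carry both 2 and 6 give the lowest numbers, and no compound here goes against that. No measurement here explains why these groups differ. 

As far as these compounds go, it remains open whether fluorine itself is needed in this pattern, which a 2,6-dichlorophenyl or 2,6-dimethylphenyl group on the same oxygen would help to show, and how a plain phenyl group would compare. From the compounds shown here alone, the pattern also rests on one read-out and one shared core, so it is unknown whether it would hold if another part of the molecule changed, for example if the carboxylic acid gave way to an amide.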